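The compounds below may be only part of what the source reports. "The series", "measured", "known", "first", "only" and "open" are said of these compounds alone.

Measured so far:
compound 1 `O=C(/C=C/c1coc2cc(O)ccc2c1=O)NCc1ccc(F)cc1` — a functional assay on L02 cells (Homo sapiens) for inhibition, read by MTT assay, with a stated time of 48 h; on this read-out higher numbers stand for weaker inhibition and lower numbers for stronger inhibition: > 200000 nM
compound 2 `COc1ccc2c(=O)c(/C=C/C(=O)Nc3ccc(Cl)cc3)coc2c1` — this assay: > 200000 nM

Compound 1 gives > 200000 nM in this assay; this is a limit of the assay, not a number. Compound 2 gives > 200000 nM in this assay, again a limit and not a number. Where compound 2 stands is thus set by the limit of > 200000 nM in this assay, at which 2 of the 2 values shown sit: it sits at the limit together with the only other value shown, and nothing on the numbers separates the two.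

Compound 3 `COc1ccc2c(=O)c(/C=C/C(=O)NCc3ccccc3F)coc2c1` differs from compound 2 by 2-fluorobenzyl in place of 4-chlorophenyl on an amide-type nitrogen. Among the measured compounds shown here, no step between measured compounds is available to size this change, and the two limits at hand give no measured difference at all. The step expected in this assay is a step that the limit leaves unreadable from compound 2 to compound 3, that is none beyond the scatter, since both points shown lie at the limit of > 200000 nM in this assay, at which 2 of the 2 values shown sit. Compound 3 is accordingly estimated at 250000 nM in this assay, with a range from 100000 nM to 600000 nM, and most probably as a further limit rather than a number.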

Compound 3, half-maximal inhibitory concentration: > 200000 nM
Compound 3: a limit, no number (the forecaster's own chance of this, stated with the estimate: 85%); the middle value does not contradict the limit.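

In this assay compound 3 gives > 200000 nM, a limit of the assay and not a number. Among the compounds shown here, no step from compound 2 to compound 3 can be read, because the values shown all sit at one limit: the limit of > 200000 nM in this assay, at which 3 of the 3 values shown sit. The compounds shown leave open whether any group on the amide-type nitrogen gives a readable number in this assay.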